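The source may hold more compounds than are shown below. What is called first, only, known or untested is meant among the compounds shown, and "the series" means these compounds.

Measured compounds:
compound 1 `Nc1cc(N)c2nc(-c3ccccc3)c(Sc3ccc(Cl)c(Cl)c3)nc2c1` gives 91200 nM
compound 2 `Nc1cc(N)c2nc(-c3ccccc3)c(Oc3ccc(F)cc3)nc2c1` gives < 100000 nM

In a functional assay on OVCAR-5 cells (Homo sapiens) for inhibition, read by sulforhodamine B assay, with a stated time of 48 h (a higher number here means that more compound is tolerated, a lower number that less compound is tolerated), compound 1 gives 91200 nM. For compound 2 the figure < 100000 nM is only a limit of the measurement and not a number. Going by the values given here, the single step between the two measured compounds, a step that the limit leaves unreadable from compound 1 to compound 2, therefore has no readable size, since the limit of < 100000 nM in this assay, at which 1 of the 2 values shown sits, covers one of the two values. Compound 2 thus stands at a point this assay cannot pin down; all that is known is the side of the limit on which it lies.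

Compound 3 `Nc1cc(N)c2nc(-c3ccccc3)c(Sc3ccc(F)cc3)nc2c1` differs from compound 2 by (4-fluorophenyl)sulfanyl in place of 4-fluorophenoxy on an aromatic carbon. Among the compounds with values here, no measured step bears directly on this exchange, and the one step that exists is unreadable, so the expectation rests only on compound 1, which also carries a sulfanyl link and sits at 91200 nM. The step that the limit leaves unreadable from compound 2 to compound 3 is expected to be small, with no clear direction beyond the usual scatter. Compound 3 is estimated at 70000 nM, with a likely range from 20000 nM to 150000 nM.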

Compound 3, concentration lethal to 50% of the cells: < 100000 nM
Compound 3: no number, only a limit; the forecaster's own chance of this, stated with the estimate: 30%; the middle value is on the limit's open side.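

In this assay compound 3 gives < 100000 nM as a limit and not a number. Going by these compounds alone, no step to compound 3 from compound 1 or compound 2 can be read: the limit of < 100000 nM in this assay, at which 2 of the 3 values shown sit. The compounds shown leave open whether (4-fluorophenyl)sulfanyl in place of 4-fluorophenoxy, or 4-fluorophenyl in place of 3,4-dichlorophenyl on the sulfur, changes how much compound the cells tolerate.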